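Compound 4 Measured Against a Shared Assay Limit

The source may hold more compounds than are shown below. What is called first, only, known or untested is meant among the compounds shown, and "the series" means these compounds.

In a functional assay on B16 cells (Mus musculus) for antiproliferative activity, with a stated time of 72 h (a higher number here means a weaker inhibitor, a lower number a stronger inhibitor), compound 1 (`OC[C@H]1O[C@@H](n2cnc3c(NCc4ccccc4Cl)ncnc32)[C@H](O)[C@@H]1O`) gives > 166000 nM as a limit. Compound 2 (`COc1ccccc1CNc1ncnc2c1ncn2[C@@H]1O[C@H](CO)[C@@H](O)[C@H]1O`) gives > 166000 nM as a limit as well. Compound 3 (`OC[C@H]1O[C@@H](n2cnc3c(NCc4ccc(Cl)c(Cl)c4)ncnc32)[C@H](O)[C@@H]1O`) gives > 166000 nM as a limit too, which places it at the limit of > 166000 nM in this assay, at which 3 of the 3 values shown sit, and no further. Compound 4 (`OC[C@H]1O[C@@H](n2cnc3c(NCc4ccc(F)cc4Cl)ncnc32)[C@H](O)[C@@H]1O`) has 2-chloro-4-fluorophenyl in place of 3,4-dichlorophenyl on a saturated chain carbon bound to a nitrogen on an aromatic ring. Both a step that the two limits leave unreadable from compound 1 to compound 3 and a step that the two limits leave unreadable from compound 2 to compound 3 change that same place but neither gives a size. In this assay the expected size is therefore a number no higher from compound 3 to compound 4 (the limit leaves the size open) with no step beyond the scatter expected and no direction favoured. Compound 4 is estimated at 166000 nM (expected range 90000 nM to 300000 nM).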

Compound 4, half-maximal inhibitory concentration: > 166000 nM
Compound 4 ended at the assay's limit (the forecaster's own chance of this, stated with the estimate: 85%); the middle value sits exactly at the limit.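

Compound 4, like compound 1, compound 2 and compound 3, stands at a limit in this assay, so no step among these compounds can be read: the limit of > 166000 nM in this assay, at which 4 of the 4 values shown sit.

The compounds shown leave open whether any group on the shared core would give a measurable value rather than a limit.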